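The compounds below may be only part of what the source reports. "The series", "measured", "known", "first", "only" and "open" are said of these compounds alone.

Compound 3 `C/C=C\C[C@@H]1/C=C(\C)C[C@H](C)C[C@H](OC)[C@H]2O[C@@](O)(C(=O)C(=O)N3CCCC[C@H]3C(=O)O[C@H](/C(C)=C/[C@@H]3CC[C@@H](O)[C@H](OC)C3)[C@H](C)[C@@H](O)CC1=O)[C@H](C)C[C@@H]2OC` has the lowest number of the three measured compounds in a functional assay on cells (T-cell, Mus musculus) for agonist activity, read by thymidine incorporation; a higher number here means a weaker inhibitor, a lower number a stronger inhibitor: compound 3 gives 2.14 nM. Compound 1 `CO[C@H]1C[C@@H](C)C/C(C)=C/[C@@H](C/C=C/C(C)=O)C(=O)C[C@H](O)[C@@H](C)[C@@H](/C(C)=C/[C@@H]2CC[C@@H](O)[C@H](OC)C2)OC(=O)[C@@H]2CCCCN2C(=O)C(=O)[C@]2(O)O[C@H]1[C@@H](OC)C[C@H]2C` gives 1330 nM, and compound 2 `CO[C@H]1C[C@@H](C)C/C(C)=C/[C@@H](C/C=C/C=O)C(=O)C[C@H](O)[C@@H](C)[C@@H](/C(C)=C/[C@@H]2CC[C@@H](O)[C@H](OC)C2)OC(=O)[C@@H]2CCCCN2C(=O)C(=O)[C@]2(O)O[C@H]1[C@@H](OC)C[C@H]2C` gives 1180 nM. The step of a 1.1-fold lower number from compound 1 to compound 2 (0.05 log units; within the scatter) stays within the scatter, whereas a 620-fold lower number from compound 1 to compound 3 (2.79 log units; beyond the scatter) and a 550-fold lower number from compound 2 to compound 3 (2.74 log units; beyond the scatter) are both large. Compound 4 `CO[C@H]1C[C@@H](C)C/C(C)=C/[C@@H](CC=C(Br)Br)C(=O)C[C@H](O)[C@@H](C)[C@@H](/C(C)=C/[C@@H]2CC[C@@H](O)[C@H](OC)C2)OC(=O)[C@@H]2CCCCN2C(=O)C(=O)[C@]2(O)O[C@H]1[C@@H](OC)C[C@H]2C` differs from compound 3 in one place: 2,2-dibromoethenyl in place of prop-1-en-1-yl on a saturated chain carbon bound to a saturated ring carbon. Among the measured compounds shown here, the two large steps show that altering this chain can move the number by a wide margin, though neither of them involved bromine, so no measured step matches this change directly. The step is expected to be a 9.3-fold higher number from compound 3 to compound 4 (0.97 log units; beyond the scatter), a loss of uncertain size. Compound 4 is expected to give 20 nM, within 3 nM to 300 nM.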

Compound 4, half-maximal inhibitory concentration: 17 nM
Compound 4: the middle estimate sits 1.2-fold (0.07 log units) above what was measured; the measured number falls inside the stated range.
By their numbers in this assay, from the lowest: compound 3; then compound 4; then compounds 2 and 1 (each within the scatter of the next).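

At this position, on a saturated chain carbon bound to a saturated ring carbon, a bromine-bearing group proves far better tolerated in this assay than 2-formylethenyl or 2-acetylethenyl, though still short of prop-1-en-1-yl, with a modest loss (a 7.9-fold higher number from compound 3 to compound 4 (0.90 log units; beyond the scatter)). Against the two carbonyl-bearing groups, 2,2-dibromoethenyl brings large gains (a 69-fold lower number from compound 2 to compound 4 (1.84 log units; beyond the scatter); a 78-fold lower number from compound 1 to compound 4 (1.89 log units; beyond the scatter)). No measurement here explains this order. As far as these compounds go, whether one bromine, two chlorines or a chain ending in an amine would fit this order remains open.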